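Replacing a Nitrile with an Ethoxy Group

The source may hold more compounds than are shown below. What is called first, only, known or untested is meant among the compounds shown, and "the series" means these compounds.

Compound 2 `COc1ccccc1-n1nc(C2CC(C)(C)OC(C)(C)C2)cc1-c1ccc(C#N)cc1` stands at the highest number of the two measured in an assay on HEK293 cells for inhibition of Voltage-dependent N-type calcium channel subunit alpha-1B (Homo sapiens), read by patch clamp, using a membrane potential dye; on this read-out higher numbers stand for weaker inhibition and lower numbers for stronger inhibition: compound 2 gives 130 nM, while compound 1 `COc1ccccc1-n1nc(C2CC(C)(C)OC(C)(C)C2)cc1-c1ccc(Cl)cc1` gives 24 nM. Going by the values given here, the only recorded step, a 5.4-fold higher number from compound 1 to compound 2 (0.73 log units; beyond the scatter), shows that the group at this position matters. Compound 3 `CCOc1ccc(-c2cc(C3CC(C)(C)OC(C)(C)C3)nn2-c2ccccc2OC)cc1` carries ethoxy in place of cyano on an aromatic carbon. Among the compounds with values here, no measured step contains an ethoxy group, so only the move away from cyano is informative. Taking the cyano out again is expected to reverse part of that step, so compound 3 is expected to show a 2.2-fold lower number from compound 2 to compound 3 (0.34 log units; beyond the scatter). The estimate for compound 3 is 60 nM, ranging from 15 nM to 250 nM.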

Compound 3, half-maximal inhibitory concentration: 61 nM
The estimate for compound 3 lay 1.0-fold (0.01 log units) below the measured number; low and high end bracket the measured number.
By their numbers in this assay, from the lowest: compound 1; then compound 3; then compound 2.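

In this assay, ethoxy in place of the nitrile on this ring brings back part of the loss seen with the nitrile (a 2.1-fold lower number from compound 2 to compound 3 (0.33 log units; beyond the scatter)). It does not match chloro, however (a 2.5-fold higher number from compound 1 to compound 3 (0.41 log units; beyond the scatter)), so among these three groups chloro gives the strongest inhibition and a polar-looking swap is not the whole story. Nothing available explains this order. Still open, going by these compounds, is whether a longer chain, such as propoxy or butoxy, would move the number further, and how an amine or a fluorine would compare at this place.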